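Aryl Group Exchanges at One Position of the Shared Core

The source may report more compounds than this note shows. Statements on the series, on what has been measured and on what is new or still open speak of the compounds shown alone.

Measured in a functional assay, with a stated time of 90 s; on this read-out lower numbers stand for stronger inhibition and higher numbers for weaker inhibition:
compound 1 `COc1ccc(-c2c3ccc4ccccc4c3nc3c2c(C)nc2c4ccccc4ccc32)cc1` — 176 ug/mL
compound 2 `Cc1nc2c3ccccc3ccc2c2nc3c(ccc4ccccc43)c(-c3cccc4ccccc34)c12` — 179 ug/mL
compound 3 `Cc1ccc(-c2c3ccc4ccccc4c3nc3c2c(C)nc2c4ccccc4ccc32)cc1` — 192 ug/mL

Compound 2 stands second highest of the three numbers, nearest compound 1 and furthest compound 3, with both gaps within the scatter. The next entry is compound 4 `Cc1nc2c3ccccc3ccc2c2nc3c(ccc4ccccc43)c(-c3cc(O)nc4ccccc34)c12`, which differs from compound 2 in one place: 2-hydroxyquinolin-4-yl in place of naphthalen-1-yl on an aromatic carbon. All three measured steps exchange the group at this same position: a 1.0-fold higher number from compound 1 to compound 2 (0.01 log units; within the scatter), a 1.1-fold higher number from compound 1 to compound 3 (0.04 log units; within the scatter), a 1.1-fold higher number from compound 2 to compound 3 (0.03 log units; within the scatter). None moved the number beyond the scatter. Among the compounds with values here, no measured step, however, introduces a hydrogen-bond donor or a ring with a hetero atom at this position, so the 2-hydroxyquinolin-4-yl group has no precedent. The expected step is therefore a 1.0-fold higher number from compound 2 to compound 4 (0.01 log units; within the scatter), with a range widened for that lack of precedent. Compound 4 is estimated at 185 ug/mL, between 95 ug/mL and 360 ug/mL.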

Compound 4, half-maximal inhibitory concentration: 148 ug/mL
The estimate for compound 4 lay 1.3-fold (0.10 log units) above the measured number; the measured number falls inside the stated range.
By their numbers in this assay, from the lowest: compounds 4, 1, 2 and 3 (each within the scatter of the next).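

In this assay the 2-hydroxyquinolin-4-yl group places a hydrogen-bond donor and a ring with a hetero atom on this aromatic carbon, yet every step to it stays within the scatter (a 1.2-fold lower number from compound 2 to compound 4 (0.08 log units; within the scatter); a 1.3-fold lower number from compound 3 to compound 4 (0.11 log units; within the scatter); a 1.2-fold lower number from compound 1 to compound 4 (0.08 log units; within the scatter)). The tolerance seen among carbon-ring and substituted phenyl groups therefore also holds for this one heteroaromatic group. No evidence here bears on why.

As far as these compounds go, the part played by the hydroxy group apart from the ring nitrogen remains open, as a plain quinolin-4-yl group would be needed to separate them. Also open, from the compounds shown here alone, is whether an amine or a carboxylic acid on this ring would move the number beyond the scatter.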